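The source may hold more compounds than are shown below. What is called first, only, known or untested is meant among the compounds shown, and "the series" means these compounds.

Measured compounds:
Compound 1 `CN(C)c1ccc(C#Cc2c(F)cccc2F)cn1` gives 77.9% in a functional assay on LS174T cells (Homo sapiens) for inhibition, with a stated time of 4 days, tested at 1 uM; on this read-out lower numbers stand for a weaker effect and higher numbers for a stronger effect at the one concentration tested.
Compound 2 `Fc1cccc(F)c1C#Cc1ccc(-n2cccc2)nc1` gives 80.5% in this assay.
Compound 3 `Fc1cccc(F)c1C#Cc1cnc(Cl)c2ccccc12` gives 48.1% in this assay.

Compound 3 stands lowest of the three numbers. The nearest is compound 1, which gives a number beyond the scatter higher, and the furthest is compound 2, higher still, also beyond the scatter. Between compound 1 and compound 2 there is a number 2.6 percentage points higher from compound 1 to compound 2 (within the scatter), so both nitrogen-bearing compounds sit close together and clearly above compound 3.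

Compound 4 `CNc1ncc(C#Cc2c(F)cccc2F)c2ccccc12` has not yet been measured. It differs from compound 3 in one place: methylamino in place of chloro on an aromatic carbon. Going by the values given here, the one measured step, from one nitrogen group to another nitrogen group, was small and says little about replacing chloro. What the numbers do show is that compound 1 and compound 2, the two compounds carrying a nitrogen group at the corresponding place, both sit well above compound 3 with its chloro, though their shared core is not the core of compound 3.

On that ground a rise beyond the scatter is expected in this assay. The expected step is a number 17.9 percentage points higher from compound 3 to compound 4 (beyond the scatter). Compound 4 is therefore estimated at 66%, within a range of 42% to 86%.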

Compound 4, a percentage reported as inhibition, at one concentration (the size of the read-out at that concentration, not a potency): 99.8%
For compound 4 the middle estimate is 33.8 percentage points below the measured one; measured number outside the range, above it.
By their numbers in this assay, from the lowest: compound 3; then compounds 1 and 2 (each within the scatter of the next); then compound 4.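

On the core of compound 3, the change from chloro to methylamino, next to the ring nitrogen, gives a number 51.7 percentage points higher from compound 3 to compound 4 (beyond the scatter) in this assay and shows that the group at this position can strongly change the read-out. Going by these compounds alone, the only earlier step, a number 2.6 percentage points higher from compound 1 to compound 2 (within the scatter) on a different core, exchanged one nitrogen-linked group for another and stayed within the scatter, so it gave no sign of a change this large. The data shown include no measurement that explains the size of this step.

Methylamino differs from chloro in several counted ways, including its added nitrogen and hydrogen-bond donor, so a single pair cannot show which difference matters; an ethylamino group, a methoxy group or a plain amine at the same position would help separate them. As far as these compounds go, compound 4 gives 99.8% at a single concentration, which is not a potency, so it remains open how compound 4 would rank against close analogues at lower concentrations.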